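A Trifluoromethylphenyl Triazole Variant Awaiting Its Cytotoxicity Readout

The source may report more compounds than this note shows. Statements on the series, on what has been measured and on what is new or still open speak of the compounds shown alone.

Of the compounds shown here, three have so far been tested in a functional assay on HL-60 cells (Homo sapiens) for cytotoxicity, read by MTT assay, with a stated time of 4 days; on this read-out lower numbers stand for stronger inhibition and higher numbers for weaker inhibition. Compound 2 `Cc1ccc(S(=O)(=O)Oc2ccc3c(c2C)[C@H](Cn2cc(-c4ccccn4)nn2)[C@@]24CC(=O)[C@@](C)(CC[C@@H]32)C4)cc1` gave only the limit of the assay, > 20000 nM. Compound 1 `C=C1C[C@]23C[C@@]1(O)CC[C@H]2c1ccc(OS(=O)(=O)c2ccc(C)cc2)c(C)c1[C@@H]3Cn1cc(-c2ccc(Cl)cc2)nn1` likewise gave a limit, > 20000 nM. Compound 3 `Cc1c(O)ccc2c1[C@H](Cn1cc(-c3ccccn3)nn1)[C@@]13CC(=O)[C@@](C)(CC[C@@H]21)C3` also gave a limit, > 20000 nM. For the measured compounds named here, because all three values sit at the limit of > 20000 nM in this assay, at which 3 of the 3 values shown sit, the single step between measured neighbours, a step that the two limits leave unreadable from compound 2 to compound 3, cannot be sized. Compound 4 `Cc1ccc(S(=O)(=O)Oc2ccc3c(c2C)[C@H](Cn2cc(-c4ccc(C(F)(F)F)cc4)nn2)[C@@]24CC(=O)[C@@](C)(CC[C@@H]32)C4)cc1` differs from compound 2 by 4-(trifluoromethyl)phenyl in place of pyridin-2-yl on an aromatic carbon. Going by the values given here, no measured step bears on this change, and since compound 2 itself is unreadable, neither a direction nor a size can be drawn for it in this assay. Compound 4 is therefore expected to remain around the same limit, an estimated 20000 nM (range 5000 nM to 100000 nM), which means an expected step of a number no higher from compound 2 to compound 4 (the limit leaves the size open).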

Compound 4, half-maximal inhibitory concentration: > 20000 nM
Compound 4: only a limit was reported; the forecaster's own chance of this, stated with the estimate: 80%; the middle value sits exactly at the limit.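

For the compounds shown here, compound 2 and compound 4 both gave only a limit, so no step between them can be read. The compounds shown leave open which structural change, if any, would give a measurable value in this assay.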